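The compounds below may be only part of what the source reports. "The series", "measured", "known", "first", "only" and "open" are said of these compounds alone.

Of the compounds shown here, two with a shared core have been measured in an ADME assay on microsomes from liver (Homo sapiens) for metabolic stability, read by LC-MS, using NADPH, with a stated time of 30 min, tested at 1 uM; on this read-out lower numbers stand for slow clearance and higher numbers for fast clearance. Compound 1 `CC#Cc1cncc(-c2ccc3c(c2)[C@@]2(COC(N)=N2)c2cc(C4=CCCOC4)ncc2O3)c1` gives 76 mL.min-1.g-1, and compound 2 `NC1=N[C@@]2(CO1)c1cc(NC(=O)c3ccc(Cl)cn3)ccc1Oc1cnc(Cl)cc12` gives 37 mL.min-1.g-1, the lower of the two numbers, with a gap that lies beyond the usual scatter. The next compound to be tested is compound 3 `CC#Cc1cncc(-c2ccc3c(c2)[C@@]2(COC(N)=N2)c2cc(Cl)ncc2O3)c1`. The change from compound 2 to compound 3 is 5-(prop-1-yn-1-yl)pyridin-3-yl in place of ((5-chloropyridin-2-yl)carbonyl)amino on an aromatic carbon, with 5-(prop-1-yn-1-yl)pyridin-3-yl in place of ((5-chloropyridin-2-yl)carbonyl)amino on an aromatic carbon. For the measured compounds named here, no measured pair shows this swap alone, so the size of the step in this assay can only be judged with caution. Going by the values given here, the one hint is that compound 1 also carries the 5-(prop-1-yn-1-yl)pyridin-3-yl group and gives 76 mL.min-1.g-1, although it differs from compound 3 elsewhere too. A small rise is therefore expected, one that may stay within the scatter, and the estimated step is a 1.2-fold higher number from compound 2 to compound 3 (0.09 log units; within the scatter). For compound 3 the expected value is 45 mL.min-1.g-1, with an estimated range of 20 mL.min-1.g-1 to 90 mL.min-1.g-1.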

Compound 3, intrinsic clearance in microsomes: 27 mL.min-1.g-1
Compound 3: the middle estimate sits 1.7-fold (0.22 log units) above what was measured; measured number inside the range.
By their numbers in this assay, from the lowest: compounds 3 and 2 (each within the scatter of the next); then compound 1.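

In this assay, putting 5-(prop-1-yn-1-yl)pyridin-3-yl in place of ((5-chloropyridin-2-yl)carbonyl)amino on this aromatic carbon gives a 1.4-fold lower number from compound 2 to compound 3 (0.14 log units; within the scatter), so this read-out does not separate the two groups at this position, although they differ in their rings' substituents and in the amide hydrogen that leaves. The second step concerns a different place on the shared core: swapping the six-membered non-aromatic ring with one hetero atom for one chlorine atom gives a 2.8-fold lower number from compound 1 to compound 3 (0.45 log units; beyond the scatter), a modest step that, unlike the first, lies beyond the scatter. Nothing available here explains either step in terms of what happens to these compounds in the microsomes.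

For the compounds shown here, each place has been probed by only one swap, so it remains open whether a small group on the same aromatic carbon, such as an amine or a carboxylic acid, would also stay within the scatter of compound 3. As far as these compounds go, it is also open whether the step from the chlorine to the non-aromatic ring would keep its size with ((5-chloropyridin-2-yl)carbonyl)amino in place of the 5-(prop-1-yn-1-yl)pyridin-3-yl group.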